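Shared-core series: cyclobutyl amide side chain, compound 3 outlook

The source may hold more compounds than are shown below. What is called first, only, known or untested is meant among the compounds shown, and "the series" means these compounds.

Measured so far:
Compound 1, `CNC(=O)/C(C)=C/c1ccc(NC(=O)Nc2ccc(Cl)c(C(F)(F)F)c2)cc1`: in a functional assay on A-375 cells (Homo sapiens) for inhibition, read by MTT assay, with a stated time of 120 h (a higher number here means a weaker inhibitor, a lower number a stronger inhibitor), compound 1 gives > 50000 nM, a limit of the assay and not a number.
Compound 2, `CNC(=O)/C=C(\C)c1ccc(NC(=O)Nc2ccc(Cl)c(C(F)(F)F)c2)cc1`: in this assay compound 2 gives > 50000 nM, likewise a limit of the assay.

Compound 2 therefore stands nowhere that can be placed on a scale: its value is a limit, and every value shown in the series sits at that same limit (the limit of > 50000 nM in this assay, at which 2 of the 2 values shown sit). Within the data shown here, the one measured step, a step that the two limits leave unreadable from compound 1 to compound 2, is bounded at both ends and its size cannot be read. Among the measured compounds shown here, no measured step bears on the change now considered.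

Compound 3, `O=C(CCc1ccc(NC(=O)Nc2ccc(Cl)c(C(F)(F)F)c2)cc1)NC1CCC1`, is the next compound for this assay. It differs from compound 2 by 2-(cyclobutylcarbamoyl)ethyl in place of 1-methyl-2-(methylcarbamoyl)ethenyl on an aromatic carbon. For the measured compounds named here, both earlier side chains left the compounds at the limit, and the saturated chain with the cyclobutyl amide is a larger departure than the one measured step covers, so the outcome is open. Compound 3 is expected to remain weak, with the step of an at least 1.4-fold lower number from compound 2 to compound 3 (0.15 log units; that floor lies within the scatter) expected to be unreadable against a limit. The estimate for compound 3 is 35000 nM, in the range 5000 nM to 100000 nM.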

Compound 3, half-maximal inhibitory concentration: > 50000 nM
Compound 3: a limit, no number (the forecaster's own chance of this, stated with the estimate: 60%); middle value at least 1.4-fold (0.15 log units) from the limit.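

No step among compound 1, compound 2 and compound 3 can be read, because all three stand at one limit of the assay and not at a number: the limit of > 50000 nM in this assay, at which 3 of the 3 values shown sit.

The compounds shown leave open whether any side chain on the shared core gives a measurable value, and how these three side chains would rank against one another.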